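A Methyl Added to a Compound Reported Inactive

A few compounds are considered here, and "the series" means these few. Any claim that something is new, unique, unknown or untested is made for them only; others in the source may bear on it.

Compound 1 `O=c1cc(-c2ccccc2)oc2cc(N3COc4ccccc4C3)ccc12` is the starting point. In a functional assay on MCF7 cells (Homo sapiens) for inhibition, read by MTT assay, with a stated time of 48 h (a higher number here means a weaker inhibitor, a lower number a stronger inhibitor), compound 1 gives "not active" (no number reported), so no number fixes where it stands. Two related compounds do give numbers: compound 2 `O=c1cc(-c2ccccc2)oc2ccc(N3COc4c(Cl)cc(Cl)cc4C3)cc12` gives 12000 nM in this assay, and compound 3 `COc1cccc2c1OCN(c1ccc3oc(-c4ccccc4)cc(=O)c3c1)C2` gives 17000 nM in this assay; these two values lie close to each other. Compound 4 `Cc1cccc2c1OCN(c1ccc3c(=O)cc(-c4ccccc4)oc3c1)C2` differs from compound 1 in one place: methyl in place of hydrogen on an aromatic carbon. Among the measured compounds shown here, with compound 1 giving no number and no measured step between any two compounds, the direction of this change cannot be read from what is known; any shift in this assay is expected to be small, if it appears at all. Compound 4 is expected to give about 25000 nM in this assay, within 8000 nM to 80000 nM, with a fair chance that only a limit is reported.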

Compound 4, half-maximal inhibitory concentration: 14900 nM
Compound 4: the middle estimate sits 1.7-fold (0.22 log units) above what was measured; low and high end bracket the measured number.
By their numbers in this assay, from the lowest: compounds 2, 4 and 3 (each within the scatter of the next).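

Among the compounds shown here, compound 1 gives "not active" (no number reported) in this assay and compound 4 gives 14900 nM, so no step between the two can be read. The compounds shown leave open what methyl in place of hydrogen changes, and no measurement at hand offers an explanation.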